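Swapping a Hexyl Ether for Isopropyl on Compound 1

The source may hold more compounds than are shown below. What is called first, only, known or untested is meant among the compounds shown, and "the series" means these compounds.

Of the compounds shown here, three sharing one core have been tested in a functional assay on NCI-H1650 cells (Homo sapiens) for cytotoxicity, read by MTT assay, with a stated time of 48 h; a lower number here means a stronger inhibitor, a higher number a weaker inhibitor. Compound 1 `CCCCCCOc1ccc2c(Cl)ccnc2c1` gives 2080 nM. Compound 2 `C=CCOc1ccc2c(NCCCN(C)C)ccnc2c1` gives 3120 nM, a number within the scatter of that of compound 1. Among the measured compounds shown here, compound 3 `CCCCCCOc1ccc2c(NCCN(C)C)ccnc2c1` gives 930 nM, and the single one-place step known so far, a 2.2-fold lower number from compound 1 to compound 3 (0.35 log units; beyond the scatter), concerns a change at the ring carbon, not at the ether. Compound 1 thus sits with the second highest number of the three.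

The next compound, compound 4 `CC(C)Oc1ccc2c(Cl)ccnc2c1`, keeps the chloro and changes only the ether: isopropyl in place of hexyl on an oxygen on an aromatic ring. For the measured compounds named here, no measured step touches this chain; compounds 2 and 3 differ from each other in two places, so their values alone are known. With nothing to point either way, no step beyond the scatter is expected. Compound 4 is therefore estimated at 2500 nM, within 1000 nM to 6500 nM. That estimate amounts to an expected step of a 1.2-fold higher number from compound 1 to compound 4 (0.08 log units; within the scatter).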

Compound 4, half-maximal inhibitory concentration: 2310 nM
Beside the measured number, compound 4's estimate is 1.1-fold (0.03 log units) above it, and the stated range covers the measured number.
By their numbers in this assay, from the lowest: compound 3; then compounds 1, 4 and 2 (each within the scatter of the next).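

In this assay, the ether on the shared core now has its own measured step: with the chloro kept, isopropyl in place of hexyl on an oxygen on an aromatic ring gives a 1.1-fold higher number from compound 1 to compound 4 (0.05 log units; within the scatter). The earlier compounds shown here offered no such step, and this one shows that a chain of 3 heavy atoms and a chain of 6 heavy atoms cannot be told apart at this position, at least in this pair. No evidence at hand bears on this result.

On these data alone, it remains open whether isopropyl and hexyl would also read alike with the (2-(dimethylamino)ethyl)amino group of compound 3 in place of the chloro. As far as these compounds go, it is equally open how this oxygen would tolerate a different kind of group, such as a benzyl ring or a chain ending in a carboxylic acid or an amine.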